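This account rests on a few compounds, and the source may have more. Where it says the series, first, only, none or still open, it means among the compounds named here.

Measured compounds in a functional assay on PC-3 cells (Homo sapiens) for antiproliferative activity, read by MTT assay, with a stated time of 24 h; a higher number here means a weaker inhibitor, a lower number a stronger inhibitor:

- compound 1, `Cc1ccc(-c2cn(CCC3(O)NC(=O)C(OCc4ccccc4)=C3OCc3ccccc3)nn2)cc1`: 84200 nM
- compound 2, `O=C1NC(O)(CCn2cc(C3=CCCCC3)nn2)C(OCc2ccccc2)=C1OCc1ccccc1`: 67200 nM
- compound 3, `O=C1NC(O)(CCn2cc(Cc3ccccc3)nn2)C(OCc2ccccc2)=C1OCc1ccccc1`: only a limit, no number

For compound 3 the result in this assay is the limit > 100000 nM. Going by these compounds, compound 3 therefore stands at the weak end of what was measured, and its exact position is unknown; the limit is one at which (the limit of > 100000 nM in this assay, at which 1 of the 3 values shown sits).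

Compound 4, `O=C1NC(O)(CCn2cc(-c3ccccc3)nn2)C(OCc2ccccc2)=C1OCc1ccccc1`, is not yet measured. It differs from compound 3 by phenyl in place of benzyl on an aromatic carbon.

For the measured compounds named here, two measured steps touch this change. an at least 1.1-fold higher number from compound 1 to compound 3 (0.07 log units; that floor lies within the scatter) and an at least 1.4-fold higher number from compound 2 to compound 3 (0.17 log units; that floor lies within the scatter), both toward the limit and both small. Compound 4 carries the phenyl that compound 1 carries as 4-methylphenyl, so the step from compound 3 to compound 4 is expected to roughly undo the step from compound 1 to compound 3, that is a small lowering, not clearly beyond the scatter: an at least 1.1-fold lower number from compound 3 to compound 4 (0.07 log units; that floor lies within the scatter).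

Compound 4 is thus expected to land near compound 1 in this assay, at about 85000 nM, with a likely range of 45000 nM to 160000 nM.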

Compound 4, half-maximal inhibitory concentration: > 100000 nM
Compound 4 ended at the assay's limit; the forecaster's own chance of this, stated with the estimate: 35%; middle value at least 1.1-fold (0.07 log units) from the limit.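

In this assay compound 4 gives > 100000 nM, which is a limit and not a number. Hydrogen in place of methyl on the aryl group reads as an at least 1.1-fold higher number from compound 1 to compound 4 (0.07 log units; that floor lies within the scatter), and phenyl in place of cyclohex-1-en-1-yl reads as an at least 1.4-fold higher number from compound 2 to compound 4 (0.17 log units; that floor lies within the scatter), so neither change shows a real loss, and the methyl of compound 1 is not shown to matter. The step between compound 3 and compound 4 cannot be read, so phenyl and benzyl remain unseparated on this carbon, and the set now rests largely at one limit: the limit of > 100000 nM in this assay, at which 2 of the 4 values shown sit.

Going by these compounds, how far compound 3 and compound 4 lie past that limit stays open. Also open, on these data alone, is whether an amine or a carboxylic acid on the phenyl, in place of the methyl of compound 1, would give a readable difference.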